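Swapping the Aryl Group on the Shared Core

The compounds below may be only part of what the source reports. "The series", "measured", "known", "first", "only" and "open" are said of these compounds alone.

Three compounds share one core and differ only in the aryl group attached to an aromatic nitrogen. Compound 1 `N#CC1=C(N)Oc2c(N)cc3nc4ccccc4nc3c2C12C(=O)N(Cc1cnnn1-c1ccc(F)cc1)c1ccccc12` carries a 4-fluorophenyl group. In a functional assay on A549 cells (Homo sapiens) for antiproliferative activity, read by MTT assay, with a stated time of 48 h (on this read-out higher numbers stand for weaker inhibition and lower numbers for stronger inhibition), compound 1 gives > 50000 nM, which is a limit of the assay rather than a measured number. Compound 2 `N#CC1=C(N)Oc2c(N)cc3nc4ccccc4nc3c2C12C(=O)N(Cc1cnnn1-c1ccccc1Br)c1ccccc12` carries a 2-bromophenyl group and in this assay gives 27400 nM. Compound 3 `Cc1ccc(-n2nncc2CN2C(=O)C3(C(C#N)=C(N)Oc4c(N)cc5nc6ccccc6nc5c43)c3ccccc32)cc1C` carries a 3,4-dimethylphenyl group. Compound 3 gives > 50000 nM in this assay, again only a limit of the assay. Compound 3 thus stands at the limit recorded as the limit of > 50000 nM in this assay, at which 2 of the 3 values shown sit. Among the measured steps, an at least 1.8-fold lower number from compound 1 to compound 2 (0.26 log units; that floor lies within the scatter), an at least 1.8-fold higher number from compound 2 to compound 3 (0.26 log units; that floor lies within the scatter), and a step that the two limits leave unreadable from compound 1 to compound 3. Compound 4 `N#CC1=C(N)Oc2c(N)cc3nc4ccccc4nc3c2C12C(=O)N(Cc1cnnn1-c1ccc(F)c(Cl)c1)c1ccccc12` is the next member: 3-chloro-4-fluorophenyl in place of 3,4-dimethylphenyl on an aromatic nitrogen. Within the data shown here, the steps that bear on this change are the two readable ones, and both sit at floors within the scatter, so no shift beyond the scatter is expected in this assay in either direction. Compound 4 is therefore expected near 40000 nM, within a range from 15000 nM to 120000 nM. The expected step is an at least 1.2-fold lower number from compound 3 to compound 4 (0.09 log units; that floor lies within the scatter), small, with a real chance that the assay again returns only a limit.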

Compound 4, half-maximal inhibitory concentration: 43400 nM
For compound 4 the middle estimate is 1.1-fold (0.04 log units) below the measured one; measured number inside the range.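

In this assay compound 4 gives a measured number rather than a limit, so this aryl group on the aromatic nitrogen now has two real values to compare, and a 1.6-fold higher number from compound 2 to compound 4 (0.20 log units; within the scatter) shows that 3-chloro-4-fluorophenyl and 2-bromophenyl cannot be told apart here. Chloro in place of hydrogen on an aromatic carbon gives an at least 1.1-fold lower number from compound 1 to compound 4 (0.06 log units; that floor lies within the scatter), and 3-chloro-4-fluorophenyl in place of 3,4-dimethylphenyl gives an at least 1.1-fold lower number from compound 3 to compound 4 (0.06 log units; that floor lies within the scatter); both are only floors inside the scatter, so neither change is shown to move the number. Much of the set still rests at the same limit, which leaves little room for reading differences: the limit of > 50000 nM in this assay, at which 2 of the 4 values shown sit.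

The step between the two compounds at the limit cannot be read, and the aryl groups shown carry only halogens and methyl groups, so whether an amine or a carboxylic acid on this phenyl ring would shift the number beyond the scatter stays open. Nor can these compounds separate which halogen is present from where it sits on the ring, since no two of them differ in that alone.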